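Dimethyl for bromo on the hydrazone aryl of compound 3

This account rests on a few compounds, and the source may have more. Where it says the series, first, only, none or still open, it means among the compounds named here.

Compound 3 `CN(C)CCn1cnnc1-c1cc(Oc2ccc(NC(=O)N/N=C/c3ccc(O)c(Br)c3)cc2F)ccn1` gives 450 nM in a functional assay on HT-29 cells (Homo sapiens) for cytotoxicity, read by MTT assay, with a stated time of 72 h (on this read-out higher numbers stand for weaker inhibition and lower numbers for stronger inhibition), the second highest of three numbers. Compound 1 `CN(C)CCn1cnnc1-c1cc(Oc2ccc(NC(=O)N/N=C/c3cccc(Br)c3)cc2F)ccn1` gives 380 nM and compound 2 `CN(C)CCn1cnnc1-c1cc(Oc2ccc(NC(=O)N/N=C/c3cc(Br)c(O)c(Br)c3)cc2F)ccn1` gives 2670 nM in this assay. Compound 4 `Cc1cc(/C=N/NC(=O)Nc2ccc(Oc3ccnc(-c4nncn4CCN(C)C)c3)c(F)c2)cc(C)c1O` differs from compound 3 in one place: 4-hydroxy-3,5-dimethylphenyl in place of 3-bromo-4-hydroxyphenyl on a carbon with a double bond to nitrogen. For the measured compounds named here, two steps bear on it. Adding hydroxy was a 1.2-fold higher number from compound 1 to compound 3 (0.07 log units; within the scatter), within the scatter, while moving to a 3,5-disubstituted 4-hydroxyphenyl was a 7.0-fold higher number from compound 1 to compound 2 (0.85 log units; beyond the scatter) and removing one bromo was a 5.9-fold lower number from compound 2 to compound 3 (0.77 log units; beyond the scatter). Since compound 4 again carries two groups flanking the hydroxy, a modest rise is expected, a 2.2-fold higher number from compound 3 to compound 4 (0.35 log units; beyond the scatter), though smaller than with two bromines. Compound 4 is therefore estimated at 1000 nM, within 400 nM to 2500 nM.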

Compound 4, half-maximal inhibitory concentration: 1220 nM
Estimate against measurement, compound 4: 1.2-fold (0.09 log units) below, within the range that was stated.
By their numbers in this assay, from the lowest: compounds 1 and 3 (each within the scatter of the next); then compound 4; then compound 2.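

In this assay, the rise seen with two bromo groups is not confined to bromine: 4-hydroxy-3,5-dimethylphenyl also gives a 2.7-fold higher number from compound 3 to compound 4 (0.43 log units; beyond the scatter) and a 3.2-fold higher number from compound 1 to compound 4 (0.51 log units; beyond the scatter). The two methyl groups still read lower than the two bromo groups, with a 2.2-fold lower number from compound 2 to compound 4 (0.34 log units; beyond the scatter), so at this position the kind of group counts as well as the presence of a pair. On these data alone, how 4-hydroxy-3-methylphenyl, or a methoxy or an amino group on this phenyl, would read stays open. Nothing available gives a cause for these steps.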